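The source may hold more compounds than are shown below. What is called first, only, known or untested is meant among the compounds shown, and "the series" means these compounds.

Two compounds of this series have been run in a functional assay on T47D cells (Homo sapiens) for cytotoxicity; a higher number here means a weaker inhibitor, a lower number a stronger inhibitor. Compound 1 `O=[N+]([O-])c1ccccc1NC(CO)CO` reaches only the limit of the assay, > 100000 nM, and gives no number. Compound 2 `O=[N+]([O-])c1ccc(NC(CO)CO)c([N+](=O)[O-])c1` likewise stops at the limit, > 100000 nM, with no number behind it. Within the data shown here, the single measured step, a step that the two limits leave unreadable from compound 1 to compound 2, cannot be read because the limit of > 100000 nM in this assay, at which 2 of the 2 values shown sit, holds both of its ends. Where compound 2 stands in this assay is therefore known only as a limit, not as a value.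

Compound 3 `O=[N+]([O-])c1ccc(NC(CO)CO)c(C(F)(F)F)c1` differs from compound 2 by trifluoromethyl in place of nitro on an aromatic carbon. Among the measured compounds shown here, no measured step bears on this change: the one recorded step touches a nitro group and is itself unreadable, so it supplies neither size nor direction. Any expectation for compound 3 in this assay rests on nothing but the two limits, and the expected step is a step that the limit leaves unreadable from compound 2 to compound 3, which is to say no change beyond the scatter and most probably a third limit. For compound 3 the estimate in this assay is 150000 nM, within 40000 nM to 500000 nM, with a number below the limit regarded as unlikely.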

Compound 3, half-maximal inhibitory concentration: > 100000 nM
Compound 3: only a limit was reported (the forecaster's own chance of this, stated with the estimate: 80%); the middle value lies beyond the limit too.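

In this assay compound 3 gives > 100000 nM, a limit of the assay and not a number. The step from compound 2 to compound 3 therefore cannot be read: the limit of > 100000 nM in this assay, at which 3 of the 3 values shown sit.

Still open, from the compounds shown here alone, is whether compound 1, compound 2 or compound 3 has any measurable value in this assay, and whether trifluoromethyl and nitro differ there at all.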